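This account rests on a few compounds, and the source may have more. Where it says the series, first, only, none or still open, it means among the compounds named here.

In a functional assay on HBL-100 cells (Homo sapiens) for antiproliferative activity, read by MTT assay, with a stated time of 72 h (a higher number here means a weaker inhibitor, a lower number a stronger inhibitor), compound 1 `Cc1ccc(/C=N/NC(=S)N2CCNCC2)cc1` gives 800 nM, the highest of the three numbers recorded and so the weakest inhibitor among them. Compound 2 `C/C(=N/NC(=S)N1CCNCC1)c1ccccc1` gives 290 nM in this assay, and compound 3 `C/C(=N\NC(=S)N1CCNCC1)c1ccc(Cl)cc1` gives 260 nM; each of these lies clearly below the number for compound 1, beyond the usual scatter. Compound 4 `COc1ccc(/C=N/NC(=S)N2CCNCC2)cc1` has not yet been measured. It differs from compound 1 only in methoxy in place of methyl on an aromatic carbon. Within the data shown here, no measured pair here separates a methyl from a methoxy, so there is no measured step to lean on; a change of this kind is expected to move this assay only a little, in no clear direction, probably within the scatter. Compound 4 is therefore estimated at 700 nM, with a range from 300 nM to 1600 nM. The expected step is a 1.1-fold lower number from compound 1 to compound 4 (0.06 log units; within the scatter).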

Compound 4, half-maximal inhibitory concentration: 1620 nM
Beside the measured number, compound 4's estimate is 2.3-fold (0.36 log units) below it; the whole stated range lies below it.
By their numbers in this assay, from the lowest: compounds 3 and 2 (each within the scatter of the next); then compound 1; then compound 4.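

In this assay, among these compounds, this is the first measured pair at this position, and it shows that the position is not indifferent to the group it carries: methoxy in place of methyl gives a 2.0-fold higher number from compound 1 to compound 4 (0.31 log units; beyond the scatter), a modest weakening just beyond the scatter. The change adds one oxygen and one hydrogen-bond acceptor, but no measurement here explains the shift. On these data alone, it remains open whether a hydroxyl or an amine at this place on the core of compound 1 would weaken activity further or restore it.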